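Methoxy for Chloro Carried onto a Second Core

The source may hold more compounds than are shown below. What is called first, only, known or untested is meant among the compounds shown, and "the series" means these compounds.

Three compounds have been measured in a functional assay on the whole organism (Abdomen, strain Swiss) for inhibition, with Mus musculus as the target, with stated times of 30 min, 10 min and 5 min, at a dose of 40 mg/kg by the oral route; a lower number here means a weaker effect, a higher number a stronger effect of the compound at the dose given:

compound 1, `Cc1c(C#N)c(-c2ccccc2)nn1CCCN1CCN(c2cccc(Cl)c2)CC1`: 23%
compound 2, `COc1cccc(N2CCN(CCCn3nc(-c4ccccc4)c(C#N)c3C)CC2)c1`: 34%
compound 3, `O=c1occ(-c2ccccc2)n1CCCN1CCN(c2cccc(Cl)c2)CC1`: 38%

Compound 1 and compound 2 share a core and differ in one place, (methoxy in place of chloro on an aromatic carbon), and this change gave a number 11 percentage points higher from compound 1 to compound 2 (beyond the scatter). Compound 3 is built on another core; the difference between the two cores is not broken down here. Compound 3 gives the highest of the three numbers, and its gap to compound 2 lies within the scatter.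

Compound 4, `COc1cccc(N2CCN(CCCn3c(-c4ccccc4)coc3=O)CC2)c1`, carries the same change on the core of compound 3: methoxy in place of chloro on an aromatic carbon. Because the first instance gave a number 11 percentage points higher from compound 1 to compound 2 (beyond the scatter), a step of similar size is expected, a number 8 percentage points higher from compound 3 to compound 4 (within the scatter), though a single earlier instance on a different core leaves the size uncertain. Compound 4 is therefore estimated at 46%, expected to lie between 32% and 60%.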

Compound 4, a percentage reported as inhibition, in the whole organism at one dose (the size of the read-out at that dose, not a potency): 39%
The estimate for compound 4 lay 7 percentage points above the measured number, within the range that was stated.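

On the core of compound 3, replacing 3-chlorophenyl with 3-methoxyphenyl gave a number 1 percentage points higher from compound 3 to compound 4 (within the scatter) in this assay. Set beside the earlier instance, the two steps do not differ by more than the scatter allows: the same change on two cores in this assay, a number 11 percentage points higher (beyond the scatter) from compound 1 to compound 2 and a number 1 percentage points higher (within the scatter) from compound 3 to compound 4, 10 percentage points apart, within the scatter of two such steps

So the change has not been seen to behave differently on the two cores, but this does not show that its effect carries over, as one step lies beyond the scatter and the other within it, and two cores at a single dose cannot settle the matter.

From the compounds shown here alone, it remains open how a hydroxy group or an amine on the same aromatic carbon would compare. Going by these compounds, whether a longer chain would alter the size of the step also remains open.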